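Dimethylamino at the benzamide ring of a picolinic acid amide

A few compounds are considered here, and "the series" means these few. Any claim that something is new, unique, unknown or untested is made for them only; others in the source may bear on it.

Measured so far:
compound 1 `O=C(Nc1ccccc1Cl)c1ccc(C(=O)O)nc1` gives 16300 nM;
compound 2 `O=C(Nc1cccc(Cl)c1)c1ccc(C(=O)O)nc1` gives 32200 nM;
compound 3 `O=C(Nc1ccc(C(=O)O)nc1)c1ccccc1` gives 25600 nM.

All three numbers come from an assay on isolated protein (Gallus gallus) for inhibition of transmembrane prolyl 4-hydroxylase (Homo sapiens); a lower number here means a stronger inhibitor, a higher number a weaker inhibitor. Compound 3 stands second highest of the three, with compound 2 nearest and compound 1 furthest; both gaps lie within the scatter, so no order among the three can be claimed. Compound 4 `CN(C)c1ccc(C(=O)Nc2ccc(C(=O)O)nc2)cc1` differs from compound 3 by dimethylamino in place of hydrogen on an aromatic carbon. Within the data shown here, no step between two measured compounds is known that would show what such an addition does here, so the expected step from compound 3 to compound 4 in this assay is none beyond the scatter, with an equal chance of either direction. Compound 4 is therefore estimated at 20000 nM, with a range from 7000 nM to 55000 nM. That estimate means a step of a 1.3-fold lower number from compound 3 to compound 4 (0.11 log units; within the scatter).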

Compound 4, half-maximal inhibitory concentration: 11300 nM
Compound 4: middle estimate off by 1.8-fold (0.25 log units), on the high side; measured number inside the range.
By their numbers in this assay, from the lowest: compounds 4, 1, 3 and 2 (each within the scatter of the next, the first and the last beyond it).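

Dimethylamino in place of hydrogen on the aromatic carbon para to a large group gives a 2.3-fold lower number from compound 3 to compound 4 (0.36 log units; beyond the scatter) in this assay as a modest change. Among these compounds, this is the first single change with a measured step, and it shows that this position accepts the added group with a lower number rather than a higher one. Nothing on hand accounts for the step. Going by these compounds, whether a primary amine or a methoxy group on the same carbon would give a similar step remains open. So does the effect of a longer chain on the nitrogen.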